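A few compounds are considered here, and "the series" means these few. Any claim that something is new, unique, unknown or untested is made for them only; others in the source may bear on it.

Measured so far:
- compound 1 `O=S(=O)(NCCCNCc1cccc2ccccc12)c1cc(C(F)(F)F)cc(C(F)(F)F)c1` — 1400 nM
- compound 2 `CC(C)(C)c1ccc(CNCCCNS(=O)(=O)c2cc(C(F)(F)F)cc(C(F)(F)F)c2)cc1` — 2100 nM

In a functional assay on MCF7 cells (Homo sapiens) for inhibition, read by MTT assay, with a stated time of 72 h (a higher number here means a weaker inhibitor of growth, a lower number a stronger inhibitor of growth), compound 1 gives the lowest of the two numbers, with compound 2 at a 1.5-fold higher number from compound 1 to compound 2 (0.18 log units; within the scatter). Compound 3 `O=S(=O)(NCCCNCC1COc2ccccc2O1)c1cc(C(F)(F)F)cc(C(F)(F)F)c1` is not yet measured. It differs from compound 1 as 2,3-dihydro-1,4-benzodioxin-2-yl in place of naphthalen-1-yl on a saturated chain carbon bound to an amine nitrogen. Within the data shown here, the only measured step at this position, a 1.5-fold higher number from compound 1 to compound 2 (0.18 log units; within the scatter), stayed within the scatter, so the data give little warning of a large move. Compound 3 is therefore expected to sit near compound 1, with the estimated step of a 1.8-fold higher number from compound 1 to compound 3 (0.25 log units; within the scatter). The expected value for compound 3 is 2500 nM, within 900 nM to 7000 nM.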

Compound 3, concentration for 50% growth inhibition: 2500 nM
For compound 3 middle estimate and measured number coincide at the digits printed; low and high end bracket the measured number.
By their numbers in this assay, from the lowest: compounds 1, 2 and 3 (each within the scatter of the next).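

In this assay, 2,3-dihydro-1,4-benzodioxin-2-yl brings oxygen atoms and hydrogen-bond acceptors that naphthalen-1-yl lacks, and the step reads a 1.8-fold higher number from compound 1 to compound 3 (0.25 log units; within the scatter). Set against 4-(tert-butyl)phenyl, the step reads a 1.2-fold higher number from compound 2 to compound 3 (0.08 log units; within the scatter), so a partly non-aromatic group with hetero atoms also stays within the scatter of both aromatic groups at this place. No measurement shown here offers an explanation for this result. The compounds shown leave open how a pyridin-3-yl or a cyclohexyl group on this saturated chain carbon would read in this assay.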